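This account rests on a few compounds, and the source may have more. Where it says the series, first, only, none or still open, it means among the compounds named here.

Compounds measured in a functional assay on SR cells (Homo sapiens) for cytotoxicity, read by sulforhodamine B assay, with a stated time of 48 h, tested at 0.1 uM; a lower number here means a stronger effect, a higher number a weaker effect of the compound at the concentration tested:
compound 1 `COc1ccc(-c2cc(/C=C/C(=O)c3ccc(N)cc3)[nH]n2)cc1` gives 98%;
compound 2 `COc1cc(-c2cc(/C=C/C(=O)c3ccc(N)cc3)[nH]n2)cc(OC)c1OC` gives 87%;
compound 3 `COc1ccc(C(=O)/C=C/c2cc(-c3cc(OC)c(OC)c(OC)c3)n[nH]2)cc1OC` gives 81%.

Compound 2 stands second highest of the three numbers. Its nearest neighbour is compound 3 at 81%, a difference within the scatter; the furthest is compound 1 at 98%, beyond the scatter.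

Among the compounds with values here, the only measured step, a number 6 percentage points lower from compound 2 to compound 3 (within the scatter), concerns the aryl group on the carbonyl carbon and does not bear on the change now made. Compound 4 `COc1ccc(-c2cc(/C=C/C(=O)c3ccc(N)cc3)[nH]n2)cc1OC` differs from compound 2 by hydrogen in place of methoxy on an aromatic carbon. Within the data shown here, no step of this kind exists; compound 1, with one methoxy group, gives 98%, and compound 2, with three, gives 87%. The expected value for compound 4 is 92%, range 82% to 100%, an expected step of a number 5 percentage points higher from compound 2 to compound 4 (within the scatter) within the scatter.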

Compound 4, a percentage reported as activity, at one concentration (the size of the read-out at that concentration, not a potency): 104%
The estimate for compound 4 lay 12 percentage points below the measured number; the measured number lies above the stated range.
By their numbers in this assay, from the lowest: compounds 3 and 2 (each within the scatter of the next); then compounds 1 and 4 (each within the scatter of the next).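

In this assay, within the data shown here, hydrogen in place of methoxy on this aromatic carbon weakens the effect (a number 17 percentage points higher from compound 2 to compound 4 (beyond the scatter)), the first single-place step beyond the scatter. Methoxy in place of hydrogen on an aromatic carbon gives no such separation (a number 6 percentage points higher from compound 1 to compound 4 (within the scatter)), so the two methoxy changes on this ring do not read alike. No measurement shown gives a cause for this difference.

Going by these compounds, whether hydroxy, fluorine or an amine could stand in place of this methoxy remains open. Also open, on these data alone, is whether the step holds with groups other than 4-aminophenyl on the carbonyl carbon.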